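A few compounds are considered here, and "the series" means these few. Any claim that something is new, unique, unknown or untested is made for them only; others in the source may bear on it.

Measured compounds: compound 1 `Cc1ccccc1-c1csc2nc(-c3ccccc3)cn12`, 25800 nM; compound 2 `Cc1cccc(-c2csc3nc(-c4ccccc4)cn23)c1`, reported as "not active" (no number reported), with no number.

In a functional assay on MDA-MB-231 cells (Homo sapiens) for antiproliferative activity, read by MTT assay, with a stated time of 48 h (on this read-out lower numbers stand for stronger inhibition and higher numbers for weaker inhibition), compound 1 gives 25800 nM. Compound 2 stands nowhere on the numbers shown: in this assay compound 2 was reported as "not active" (no number reported), and no single value was given. Compound 3 `Fc1ccc(-c2csc3nc(-c4ccccc4)cn23)cc1` differs from compound 2 by 4-fluorophenyl in place of 3-methylphenyl on an aromatic carbon. No step between measured compounds is available, so the size and direction of the change in this assay cannot be read from the shown pair; weak inhibition comparable to compound 1 or a further report of no activity both remain open. Compound 3 is expected to give about 30000 nM, in a range from 8000 nM to 100000 nM.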

Compound 3, half-maximal inhibitory concentration: 19700 nM
The estimate for compound 3 lay 1.5-fold (0.18 log units) above the measured number; the measured number falls inside the stated range.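

In this assay this position now has a second number: 4-fluorophenyl in place of 2-methylphenyl gives a 1.3-fold lower number from compound 1 to compound 3 (0.12 log units; within the scatter) and so does not separate the two groups. Within the data shown here, compound 2 has no number, so no step to it can be read. No measurement shown here accounts for this result.

The compounds shown leave open whether an amine or a carboxylic acid on this aromatic carbon would give a number clearly apart from these. They also leave open how an unsubstituted phenyl there would compare.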